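Adding a hydroxy group to the pyridine of compound 1

The compounds below may be only part of what the source reports. "The series", "measured", "known", "first", "only" and "open" are said of these compounds alone.

Measured compounds:
- compound 1, `O=C(O)Cc1sc(C(c2ccc(F)cc2)c2ccc(F)cc2)nc1-c1ccncc1`: 5.3 nM
- compound 2, `O=C(O)Cc1sc(C(c2ccccc2)c2ccc(Cl)cc2)nc1-c1ccc(F)cc1`: 14 nM

In an in vitro assay on HEK385-7 cells for displacement of a labelled ligand from prostaglandin D2 receptor 2 (Homo sapiens) (on this read-out higher numbers stand for weaker inhibition and lower numbers for stronger inhibition), compound 1 gives 5.3 nM, the lowest of the two numbers measured; the nearest is compound 2 with 14 nM, a gap that lies beyond the usual scatter, so compound 1 is the stronger inhibitor of the pair. Compound 2 also differs from compound 1 in several places at once, so nothing can be read from it about any single change.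

Compound 3, `O=C(O)Cc1sc(C(c2ccc(F)cc2)c2ccc(F)cc2)nc1-c1ccnc(O)c1`, has not yet been measured. It differs from compound 1 in one place: hydroxy in place of hydrogen on an aromatic carbon, on the six-membered aromatic ring with one nitrogen, next to the ring nitrogen. Among the measured compounds shown here, no measured pair shows what such a change does here, so the size of the step is open. A modest weakening is expected, a 1.5-fold higher number from compound 1 to compound 3 (0.18 log units; within the scatter), though a result within the scatter would not surprise. Compound 3 is thus estimated at 8 nM, with a range from 2.5 nM to 25 nM.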

Compound 3, half-maximal inhibitory concentration: 68 nM
For compound 3 the middle estimate is 8.5-fold (0.93 log units) below the measured one; the whole stated range lies below it.
By their numbers in this assay, from the lowest: compound 1; then compound 2; then compound 3.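

Putting a hydroxy group in place of hydrogen on the aromatic carbon next to the ring nitrogen gives a 13-fold higher number from compound 1 to compound 3 (1.11 log units; beyond the scatter) in this assay. Since higher numbers here mean weaker inhibition, this single added oxygen clearly weakens binding, so this position does not accept every change freely. Compound 2 could not show this, as it differs from compound 1 in several places at once, and nothing measured here explains why the step is so large.

Going by these compounds, it remains open whether this weakening is specific to hydroxy or would also follow from other groups on the same carbon, such as an amine, a methoxy group or a fluorine atom. On these data alone, it is equally open whether a hydroxy group on another carbon of this ring would give a step of similar size.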